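Two sugar-derived triazoles and a third awaiting its number

The source may hold more compounds than are shown below. What is called first, only, known or untested is meant among the compounds shown, and "the series" means these compounds.

Of the compounds shown here, two of a shared core have been tested in a functional assay on MCF7 cells (Homo sapiens) for antiproliferative activity, read by MTT assay, with a stated time of 72 h; on this read-out higher numbers stand for weaker inhibition and lower numbers for stronger inhibition. Compound 1 (`O=C1O/C(=C\Cn2cc(-c3ccc(Br)cc3)nn2)C(OCc2ccccc2)=C1OCc1ccccc1`) reaches only a limit of the assay: compound 1 gives > 100000 nM, which means no number was obtained for it. Within the data shown here, compound 2 (`O=C1O[C@H]([C@@H](O)Cn2cc(CNS(=O)(=O)c3ccc(F)cc3)nn2)C(OCc2ccccc2)=C1OCc1ccccc1`) gives 26800 nM in this assay, and that is the only true number among the two values shown. The other value is that of compound 1, which sits at the limit of > 100000 nM in this assay, at which 1 of the 2 values shown sits. Among the measured compounds shown here, compound 2 therefore stands alone as the one compound with a measured potency, with nothing to rank it against.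

Compound 3 (`O=C1O[C@H]([C@@H](O)Cn2cc(-c3cc(F)cc(F)c3)nn2)C(OCc2ccccc2)=C1OCc1ccccc1`) differs from compound 2 at a single place on the five-membered ring with three nitrogens: 3,5-difluorophenyl in place of (((4-fluorophenyl)sulfonyl)amino)methyl on an aromatic carbon. For the measured compounds named here, no measured pair shows what such a swap does on this core, so there is no step to lean on. The expectation for the change from compound 2 to compound 3 is a step of a 1.1-fold higher number from compound 2 to compound 3 (0.05 log units; within the scatter), most likely within the scatter, in either direction. Compound 3 is estimated at 30000 nM in this assay, within a range from 8000 nM to 100000 nM.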

Compound 3, half-maximal inhibitory concentration: 27700 nM
The estimate for compound 3 lay 1.1-fold (0.03 log units) above the measured number; the range from low to high includes it.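

The swap on this aromatic carbon of the five-membered ring gives, in this assay, a 1.0-fold higher number from compound 2 to compound 3 (0.01 log units; within the scatter), so this read-out does not tell compound 2 and compound 3 apart. Among these compounds, this is the first measured comparison at this place, and it shows that two quite different groups can read alike here: (((4-fluorophenyl)sulfonyl)amino)methyl, with 12 heavy atoms, 1 hydrogen-bond donor and 2 hydrogen-bond acceptors, and 3,5-difluorophenyl, with 8 heavy atoms and neither donors nor acceptors. Nothing measured here bears on why the two groups read alike.

Going by these compounds, both groups contain a six-membered aromatic ring of carbon only that carries fluorine, so it remains open whether a group without such a ring at this place, such as an aminomethyl group or a longer alkyl chain, would read the same. On these data alone, it also remains open whether a carboxylic acid here, or a phenyl ring with no fluorine, would give a number beyond the scatter of compound 2 and compound 3.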